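The source may hold more compounds than are shown below. What is called first, only, known or untested is meant among the compounds shown, and "the series" means these compounds.

Measured so far in a functional assay on DU-145 cells (Homo sapiens) for inhibition, read by trypan blue exclusion, with a stated time of 96 h; a higher number here means a weaker inhibitor of growth, a lower number a stronger inhibitor of growth:
Compound 1 `Cc1ccc(CS/C(=C/c2c(O)cc(O)cc2O)C(=O)c2ccc(Cl)cc2)cc1` gives 50000 nM.
Compound 2 `O=C(/C(=C\c1c(O)cc(O)cc1O)S(=O)(=O)c1ccccc1Br)c1ccc(Cl)cc1` gives 50000 nM.
Compound 3 `Cc1ccc(S/C(=C/c2c(O)cc(O)cc2O)C(=O)c2ccc(Cl)cc2)cc1` gives only a limit of the assay, not a number: > 100000 nM.

Compound 1 stands level with compound 2, as the step from compound 1 to compound 2 shows: no change at the digits printed from compound 1 to compound 2 (within the scatter). The step from compound 1 to compound 3 was an at least 2.0-fold higher number from compound 1 to compound 3 (0.30 log units; that floor lies within the scatter), and the step from compound 2 to compound 3 was an at least 2.0-fold higher number from compound 2 to compound 3 (0.30 log units; that floor lies within the scatter); both rest on the limit recorded for compound 3, (the limit of > 100000 nM in this assay, at which 1 of the 3 values shown sits).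

Compound 4 `Cc1ccc(CS/C(=C/c2ccccc2Br)C(=O)c2ccc(Cl)cc2)cc1` is not yet measured. It differs from compound 1 in one place: 2-bromophenyl in place of 2,4,6-trihydroxyphenyl on a double-bonded chain carbon bound to a double-bonded chain carbon. For the measured compounds named here, the two measured steps both changed the group carried by the sulfur, not the 2,4,6-trihydroxyphenyl, so no measured step bears directly on this change. Going by the values given here, all three measured compounds are weak in this assay, and no measured step moved a value beyond the scatter, so the expected step from compound 1 to compound 4 is small: a 1.6-fold higher number from compound 1 to compound 4 (0.20 log units; within the scatter). For compound 4 the estimate is 80000 nM, with a range from 30000 nM to 300000 nM.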

Compound 4, concentration for 50% growth inhibition: 10000 nM
Compound 4: the middle estimate sits 8.0-fold (0.90 log units) above what was measured, outside the stated range (below it).
By their numbers in this assay, from the lowest: compound 4; then compounds 1 and 2 (each within the scatter of the next). At a limit, above all of these: compound 3.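

In this assay, for the compounds shown here, putting 2-bromophenyl in place of 2,4,6-trihydroxyphenyl gives a 5.0-fold lower number from compound 1 to compound 4 (0.70 log units; beyond the scatter) and is the first step here that clearly lies beyond the scatter. Going by these compounds alone, it is also the first change at this place, on a double-bonded chain carbon bound to a double-bonded chain carbon, rather than in the group on the sulfur, and it shows that growth inhibition does not depend on the 2,4,6-trihydroxyphenyl and its hydrogen-bond donors. Nothing measured here explains why this change gives the stronger inhibitor of growth.

From the compounds shown here alone, what remains open is whether the gain comes from losing the hydroxyl groups or from gaining the bromine; a plain phenyl or a 2-aminophenyl at this place would help separate the two. Going by these compounds, it is also open whether 2-bromophenyl would give a similar step in compound 2 or compound 3, which carry other groups in the sulfur position.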